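Ring hydroxy removal in a thymine nucleotide series

A few compounds are considered here, and "the series" means these few. Any claim that something is new, unique, unknown or untested is made for them only; others in the source may bear on it.

Measured so far:
compound 1 `Cc1cn([C@H]2C[C@H](CF)[C@@H](COP(=O)(O)O)O2)c(=O)[nH]c1=O` — 40000 nM
compound 2 `Cc1cn([C@@H]2O[C@H](COP(=O)(O)O)[C@@H](CN)[C@H]2O)c(=O)[nH]c1=O` — 280000 nM
compound 3 `Cc1cn([C@@H]2O[C@H](CO)[C@@H](CN)[C@H]2O)c(=O)[nH]c1=O` — 110000 nM

In an assay on isolated protein for inhibition of thymidine kinase, cytosolic (Homo sapiens) (on this read-out lower numbers stand for stronger inhibition and higher numbers for weaker inhibition), compound 2 gives the highest number of the three, so it is the weakest inhibitor in this set. Among the measured compounds shown here, the only single-point step measured, a 2.5-fold lower number from compound 2 to compound 3 (0.41 log units; beyond the scatter), removes the phosphate and leaves the ring untouched. Compound 1 and compound 2 differ in two places, so their values can only be set side by side: in this assay compound 1 gives 40000 nM, whereas compound 2 gives 280000 nM.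

Compound 4 `Cc1cn([C@H]2C[C@H](CN)[C@@H](COP(=O)(O)O)O2)c(=O)[nH]c1=O` differs from compound 2 by hydrogen in place of hydroxy on a saturated ring carbon. For the measured compounds named here, no measured step covers this change; the step of a 2.5-fold lower number from compound 2 to compound 3 (0.41 log units; beyond the scatter) concerns the phosphate and gives no guidance here. Compound 1 also lacks this hydroxy and gives 40000 nM, but it carries a fluoromethyl group rather than an aminomethyl group, so it is only a loose pointer. A move toward the number of compound 1 is expected, with wide uncertainty. Compound 4 is therefore estimated at 70000 nM, within a range from 15000 nM to 300000 nM. The expected step is a 4.0-fold lower number from compound 2 to compound 4 (0.60 log units; beyond the scatter).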

Compound 4, inhibition constant: 4700 nM
Compound 4: middle estimate off by 15-fold (1.17 log units), on the high side; measured number outside the range, below it.
By their numbers in this assay, from the lowest: compound 4; then compound 1; then compound 3; then compound 2.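

In this assay, the hydroxy on the saturated ring carbon turns out to matter more than the phosphate: the step for its loss, a 60-fold lower number from compound 2 to compound 4 (1.78 log units; beyond the scatter), is larger than the step for removing the phosphate, a 2.5-fold lower number from compound 2 to compound 3 (0.41 log units; beyond the scatter). Without this hydroxy, the group on the chain carbon also separates the compounds, with amino in place of fluoro giving an 8.5-fold lower number from compound 1 to compound 4 (0.93 log units; beyond the scatter), a comparison that compound 2 and compound 1 could not provide on their own. No measurement at hand bears on the reason for either step.

The effect of removing the phosphate is shown only with the hydroxy in place, so its size without the hydroxy remains open. Also open, on these data alone, is how a methoxy group on that ring carbon, or an aminoethyl chain in place of aminomethyl, would read in this assay.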